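Fluoro for chloro on an aminotriazine-fused nucleoside

This account rests on a few compounds, and the source may have more. Where it says the series, first, only, none or still open, it means among the compounds named here.

The shared core of compound 1 `C[C@@]1(O)[C@H](O)[C@@H](CO)O[C@H]1c1cnc2c(N)ncnn12` carries a methyl-bearing sugar and an amino group on the fused bicyclic base. In an ADME assay on Huh-7 cells (Homo sapiens) for cytotoxicity (on this read-out lower numbers stand for higher toxicity in this test and higher numbers for lower toxicity in this test), compound 1 gives 26000 nM. Compound 2 `C[C@@]1(O)[C@H](O)[C@@H](CO)O[C@H]1c1ccc2c(N)nc(N)nn12`, with a second amino group and an altered ring, reaches only the limit of the test, giving > 100000 nM in this assay. Compound 3 `C[C@@]1(O)[C@H](O)[C@@H](CO)O[C@H]1c1cnc2c(N)nc(Cl)nn12`, in which chloro replaces hydrogen on an aromatic carbon, likewise sits at the limit, giving > 100000 nM in this assay. The step of an at least 3.8-fold higher number from compound 1 to compound 3 (0.58 log units; beyond the scatter) is therefore bounded by the limit of > 100000 nM in this assay, at which 2 of the 3 values shown sit, and compound 3 stands at the least toxic end of what is shown, tied with compound 2.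

Compound 4 `C[C@@]1(O)[C@H](O)[C@@H](CO)O[C@H]1c1cnc2c(N)nc(F)nn12` differs from compound 3 by fluoro in place of chloro on an aromatic carbon. For the measured compounds named here, only the step from compound 1 to compound 3 bears on a halogen at this carbon, and it moved the number away from toxicity. A fluoro in the same place is expected to leave compound 3's limit essentially in force, so the step of a number no higher from compound 3 to compound 4 (the limit leaves the size open) is estimated to be none beyond the scatter. For compound 4 the expected value in this assay is 100000 nM, within 40000 nM to 300000 nM.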

Compound 4, half-maximal cytotoxic concentration: > 100000 nM
Compound 4: no number, only a limit; the forecaster's own chance of this, stated with the estimate: 65%; the middle value sits exactly at the limit.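

With fluoro on the aromatic carbon between two ring nitrogen atoms, the shared core again shows an at least 3.8-fold higher number from compound 1 to compound 4 (0.58 log units; beyond the scatter) in this assay, so the rise seen with chloro at this carbon is not tied to chloro alone. Compound 3 and compound 4 both stand at a limit, and the step between them cannot be read, so chloro and fluoro cannot be put in any order here. The read-out at this carbon is now capped for both halogens, and the set as a whole sits largely at the same ceiling: the limit of > 100000 nM in this assay, at which 3 of the 4 values shown sit.

From the compounds shown here alone, how far beyond the limit either halogen lies remains open. So does whether the rise belongs to halogens in particular or would also appear with a methoxy group or a nitrile on the same carbon.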